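The compounds below may be only part of what the source reports. "The series", "measured", "known", "first", "only" and "open" are said of these compounds alone.

Compound 1 `CC(C)n1nc2c(c1-c1ccccc1)CCNCC2` is one of three close relatives measured in an ADME assay on membranes from Cortex for displacement of a labelled ligand from Adrenergic receptor alpha-1 (Rattus norvegicus), read by radioligand binding, with a stated time of 60 min; a lower number here means a stronger inhibitor, a higher number a weaker inhibitor. In this assay compound 1 gives 530 nM. Compound 2 `c1ccc(-c2c3c(nn2C2CC2)CCNCC3)cc1` gives 600 nM, and compound 3 `c1ccc(-c2c3c(nn2C2CCC2)CCNCC3)cc1` gives 500 nM, so compound 1 stands second highest of the three, with all three numbers lying within the usual scatter of one another. The steps of a 1.1-fold higher number from compound 1 to compound 2 (0.05 log units; within the scatter) and a 1.1-fold lower number from compound 1 to compound 3 (0.03 log units; within the scatter) each change only the group on the aromatic nitrogen, and neither moves the number beyond the scatter; the same holds for a 1.2-fold lower number from compound 2 to compound 3 (0.08 log units; within the scatter).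

Compound 4 `Cc1ccc(-c2c3c(nn2C(C)C)CCNCC3)cc1` has not yet been measured. It differs from compound 1 by methyl in place of hydrogen on an aromatic carbon. Within the data shown here, none of the measured steps touches that six-membered ring of compound 1; the three steps that exist concern the group on the aromatic nitrogen at the other end of the shared core, and all of them lie within the scatter. These numbers therefore give no ground for expecting a step in either direction beyond the scatter, nor any ground for ruling one out. Compound 4 is expected to give about 400 nM in this assay, with a range from 150 nM to 1200 nM. That estimate amounts to a 1.3-fold lower number from compound 1 to compound 4 (0.12 log units; within the scatter), a step not expected to exceed the scatter.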

Compound 4, inhibition constant: 4 nM
Compound 4: middle estimate off by 100-fold (2.00 log units), on the high side; the measured number lies below the stated range.
By their numbers in this assay, from the lowest: compound 4; then compounds 3, 1 and 2 (each within the scatter of the next).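

In this assay, methyl in place of hydrogen on an aromatic carbon of the six-membered aromatic ring of carbon only, para to a large group, gives a 130-fold lower number from compound 1 to compound 4 (2.12 log units; beyond the scatter), which means a much stronger inhibitor. Among the compounds shown, this position responds far more than the aromatic nitrogen, where swapping among isopropyl, cyclopropyl and cyclobutyl left every step within the scatter. The entering group is only one heavy atom, with no ring, no hydrogen-bond donors or acceptors and no net charge, so even a very small addition at this place can shift the number by a large amount, and nothing available here accounts for why the step is so large.

The compounds shown leave open whether this shift is particular to methyl or would also appear with another group at the same place, such as an ethyl group, a chlorine atom or a methoxy group. They also leave open whether the same methyl would give a step of similar size with cyclopropyl or cyclobutyl on the aromatic nitrogen.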